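From a 4-Chlorophenyl to a 2-Methoxyphenyl Group

This account rests on a few compounds, and the source may have more. Where it says the series, first, only, none or still open, it means among the compounds named here.

Compound 1, `COc1cc2ncnc(NNC(=S)NC(=O)c3ccccc3C)c2cc1OC`, gives 19300 nM in a functional assay on MCF7 cells (Homo sapiens) for cytotoxicity, read by MTT assay, with a stated time of 72 h; a higher number here means a weaker inhibitor, a lower number a stronger inhibitor.
Compound 2, `COc1cc2ncnc(NNC(=S)NC(=O)c3ccccc3Cl)c2cc1OC`, gives 23100 nM in this assay.
Compound 3, `COc1cc2ncnc(NNC(=S)NC(=O)c3ccc(Cl)cc3)c2cc1OC`, gives 8940 nM in this assay.

Among these three, compound 3 has the lowest number, and both of its neighbours lie beyond the scatter: a 2.2-fold lower number from compound 1 to compound 3 (0.33 log units; beyond the scatter) and a 2.6-fold lower number from compound 2 to compound 3 (0.41 log units; beyond the scatter). Compound 1 and compound 2, by contrast, sit within the scatter of each other, a 1.2-fold higher number from compound 1 to compound 2 (0.08 log units; within the scatter), so nothing separates the 2-methylphenyl from the 2-chlorophenyl here.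

Compound 4, `COc1cc2ncnc(NNC(=S)NC(=O)c3ccccc3OC)c2cc1OC`, has not yet been measured. It differs from compound 3 in one place: 2-methoxyphenyl in place of 4-chlorophenyl on a carbonyl carbon.

The two steps that bear on this change both run from a phenyl carrying a group at the 2-position to the 4-chlorophenyl, and both lowered the number by a modest amount. Compound 4 goes the other way, back to a phenyl substituted at the 2-position, so a modest rise in the number is expected, of about the size seen in those two steps. For compound 4 the step is estimated as a 2.2-fold higher number from compound 3 to compound 4 (0.35 log units; beyond the scatter). The expected value for compound 4 is 20000 nM, within a range from 8000 nM to 50000 nM.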

Compound 4, half-maximal inhibitory concentration: 8800 nM
Compound 4: the middle estimate sits 2.3-fold (0.36 log units) above what was measured, within the range that was stated.
By their numbers in this assay, from the lowest: compounds 4 and 3 (each within the scatter of the next); then compounds 1 and 2 (each within the scatter of the next).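

The 2-methylphenyl and 2-chlorophenyl groups of compound 1 and compound 2 both gave higher numbers than the 4-chlorophenyl group of compound 3, which could have suggested that any phenyl named with a 2-substituent would do the same, but the 2-methoxyphenyl group of compound 4 goes against that reading: in this assay the exchange of 4-chlorophenyl for 2-methoxyphenyl on the carbonyl carbon changes nothing that can be told from the scatter (a 1.0-fold lower number from compound 3 to compound 4 (0.01 log units; within the scatter)). The identity of the group on the aromatic carbon therefore matters among these compounds, since methoxy in place of chloro gives a modest drop (a 2.6-fold lower number from compound 2 to compound 4 (0.42 log units; beyond the scatter)) and methoxy in place of methyl gives one of similar size (a 2.2-fold lower number from compound 1 to compound 4 (0.34 log units; beyond the scatter)). Nothing measured here accounts for this difference between methoxy and the other two groups.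

The compounds shown leave open whether a 4-methoxyphenyl group would match compound 4 or compound 3 in this assay. They also leave open how an unsubstituted phenyl, or a phenyl carrying an amine or a carboxylic acid, would behave on the same carbonyl carbon.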